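From compound 1 to compound 4: one arm exchanged

The compounds below may be only part of what the source reports. "The series", "measured", "known", "first", "only" and "open" are said of these compounds alone.

Compound 1 `COC(=O)/C=C/c1cccc(N(Cc2ccc(/C=C/c3cccc(Cl)c3)cc2)C(=O)C2CCCCC2)c1` was tested in an assay on isolated protein with Bile acid receptor (Homo sapiens) as the target (on this read-out higher numbers stand for an effect only at larger amounts of compound and lower numbers for an effect already at smaller amounts), and compound 1 gives 166 nM in this read-out. Among the three measured compounds this is the second highest number. Compound 2 `COC(=O)/C=C/c1cccc(N(Cc2ccc(/C=C/c3cccc(Cl)c3)cc2)C(=O)C(C)C)c1` gives 162 nM, and there is a 1.0-fold lower number from compound 1 to compound 2 (0.01 log units; within the scatter) between the two. Compound 3 `COC(=O)/C=C/c1cccc(N(Cc2ccc(/C=C/c3cccc(F)c3)cc2)C(=O)NC(C)C)c1` differs from compound 1 in two places; compound 3 gives 468 nM, a higher number beyond the scatter. Compound 4 `COC(=O)/C=C/c1cccc(N(Cc2ccc(-c3cccc(OC(F)(F)F)c3)cc2)C(=O)C2CCCCC2)c1` differs from compound 1 by 3-(trifluoromethoxy)phenyl in place of 2-(3-chlorophenyl)ethenyl on an aromatic carbon. Among the measured compounds shown here, no measured step touches this arm of the shared core, and the single one-place step known lies within the scatter, so nothing measured bears directly on the change. A move in either direction is possible, and the expected step of a 1.8-fold higher number from compound 1 to compound 4 (0.26 log units; within the scatter) is therefore modest and uncertain. Compound 4 is estimated at 300 nM, with a range from 80 nM to 1200 nM.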

Compound 4, half-maximal effective concentration: 417 nM
Estimate against measurement, compound 4: 1.4-fold (0.14 log units) below; measured number inside the range.
By their numbers in this assay, from the lowest: compounds 2 and 1 (each within the scatter of the next); then compounds 4 and 3 (each within the scatter of the next).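

The earlier one-place step stayed within the scatter, but this arm of the shared core does register in this assay, with a 2.5-fold higher number from compound 1 to compound 4 (0.40 log units; beyond the scatter). A change at this aromatic carbon can therefore move the number, although only modestly here. Nothing available explains the step.

The exchange removes the double bond and also replaces chlorine with trifluoromethoxy, so the compounds shown cannot separate these two changes. On these data alone, how an amine or a carboxylic acid in place of the trifluoromethoxy group would read remains open.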